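The source may hold more compounds than are shown below. What is called first, only, known or untested is meant among the compounds shown, and "the series" means these compounds.

Series notes. All members share one core, with an amino substituent on an aromatic carbon and a substituted aryl group; three have been measured in an assay on cell membranes for displacement of a labelled ligand from corticotropin-releasing factor receptor 1 (Rattus norvegicus); a lower number here means a stronger inhibitor, a higher number a weaker inhibitor. Compound 1 `CCC(CC)Nc1nc(C)nc2c(-c3cc(F)c(OC)cc3C)c(C)nn12` gives 1.9 nM in this assay. Compound 2 `C=CCN(CC=C)c1nc(C)nc2c(-c3c(C)cc(OC)cc3OC)c(C)nn12` gives 1 nM. Compound 3 `CCCN(CCC#N)c1nc(C)nc2c(-c3ccc(OC)cc3C)c(C)nn12` gives 2.16 nM. Compound 2 has the lowest number of the three: compound 1 sits within the scatter of it, while compound 3 lies beyond the scatter, so only against compound 3 can compound 2 be read as the stronger inhibitor.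

Compound 4 `CCCC(C)Nc1nc(C)nc2c(-c3c(C)cc(OC)cc3OC)c(C)nn12` keeps the aryl group of compound 2 and alters the amino substituent: (1-methylbutyl)amino in place of diallylamino on an aromatic carbon. For the measured compounds named here, no pair of measured compounds isolates this change. The nearest guide is the analogue closest to compound 4 in its amino substituent, compound 1, which gives 1.9 nM and stands within the scatter of compound 2. Compound 4 is therefore expected to stay near compound 2 in this assay, the expected step being a 2.0-fold higher number from compound 2 to compound 4 (0.30 log units; within the scatter), inside the scatter. The estimate for compound 4 is 2 nM, in a range from 0.8 nM to 5 nM.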

Compound 4, half-maximal inhibitory concentration: 2.14 nM
Estimate against measurement, compound 4: 1.1-fold (0.03 log units) below, within the range that was stated.
By their numbers in this assay, from the lowest: compounds 2, 1, 4 and 3 (each within the scatter of the next, the first and the last beyond it).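

For the compounds shown here, with the aryl group held constant, compounds 2 and 4 form the first pair that differs in one place, and in this assay the pair gives a 2.1-fold higher number from compound 2 to compound 4 (0.33 log units; beyond the scatter). On the aromatic carbon between two ring nitrogen atoms, the (1-methylbutyl)amino group therefore gives a modestly higher number than diallylamino, though the change is small given that it removes both double bonds and adds a hydrogen-bond donor. Going by these compounds alone, the single swap changes these features together, and nothing available bears on which of them accounts for the step.

Going by these compounds, whether the step carries over to the aryl groups of compound 1 and compound 3 remains open. So does the response at this position to a morpholine ring or to a longer unbranched alkylamino chain.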